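The source may report more compounds than this note shows. Statements on the series, on what has been measured and on what is new or still open speak of the compounds shown alone.

Compound 1 `Cc1ncc([N+](=O)[O-])n1CCSc1nnc(-c2ccccc2N)o1`: 4500 nM
Compound 2 `CCOc1ccccc1-c1nnc(SCCn2c([N+](=O)[O-])cnc2C)o1`: 9800 nM
Compound 3 `CCOc1ccc(-c2nnc(SCCn3c([N+](=O)[O-])cnc3C)o2)cc1`: 1900 nM

These values come from a functional assay on HepG2 cells (Homo sapiens) for cytotoxicity, read by MTT assay, with a stated time of 48 h; a higher number here means a weaker inhibitor, a lower number a stronger inhibitor. Compound 1 sits in the middle of the three, with compound 2 giving a higher number and compound 3 a lower one. Still unmeasured is compound 4 `Cc1ccc(-c2nnc(SCCn3c([N+](=O)[O-])cnc3C)o2)c(O)c1`, which keeps the core of compound 1 and changes one group: 2-hydroxy-4-methylphenyl in place of 2-aminophenyl on an aromatic carbon. For the measured compounds named here, the one measured step that bears directly on this change is a 2.2-fold higher number from compound 1 to compound 2 (0.34 log units; beyond the scatter), a modest step with ethoxy in place of amino. Compound 3 also carries an ethoxy group, yet compound 3 gives 1900 nM, so replacing the 2-aminophenyl group has moved the number both ways among these compounds, each time by a modest amount. With no clear direction to follow, no change beyond the scatter is expected in this assay, and the expected step is a 1.1-fold lower number from compound 1 to compound 4 (0.03 log units; within the scatter). For compound 4 the estimated value is 4200 nM, with an expected range from 1700 nM to 10000 nM.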

Compound 4, half-maximal inhibitory concentration: 16600 nM
Beside the measured number, compound 4's estimate is 4.0-fold (0.60 log units) below it, outside the stated range (above it).
By their numbers in this assay, from the lowest: compound 3; then compound 1; then compounds 2 and 4 (each within the scatter of the next).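

In this assay, for the compounds shown here, putting 2-hydroxy-4-methylphenyl in place of 2-aminophenyl gives a 3.7-fold higher number from compound 1 to compound 4 (0.57 log units; beyond the scatter), a clear shift at a position where the earlier compounds had pointed in no single direction. Both groups carry the same counts of hydrogen-bond donors and acceptors and no net charge, so those counts alone do not track the number here. Compounds 2 and 4 now both give higher numbers than compound 1, while compound 3 goes against this trend at 1900 nM, so a replacement at this position does not by itself set the direction.

No measured evidence here accounts for the step. From the compounds shown here alone, how much of it belongs to the hydroxy and how much to the methyl stays open, and a 2-hydroxyphenyl group, without the methyl, would separate the two.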